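Trifluoromethyl on the Aromatic Ring of a Cyclohexane Ester

A few compounds are considered here, and "the series" means these few. Any claim that something is new, unique, unknown or untested is made for them only; others in the source may bear on it.

Compound 1 `COC(=O)[C@@H]1CCCC[C@@H]1c1ccc(C(C)(C)C)cc1`: 766000 nM
Compound 2 `COC(=O)[C@@H]1CCCC[C@@H]1c1ccc(OC(F)(F)F)cc1`: 1180000 nM
Compound 3 `COC(=O)[C@@H]1CCCC[C@@H]1c1ccccc1`: 975000 nM

In an assay on COS-1 cells for displacement of a labelled ligand from sodium-dependent dopamine transporter (Homo sapiens) (on this read-out higher numbers stand for weaker inhibition and lower numbers for stronger inhibition), compound 3 holds the second highest of the three numbers. Its nearest neighbour is compound 2 (a 1.2-fold lower number from compound 2 to compound 3 (0.08 log units; within the scatter)), its furthest compound 1 (a 1.3-fold higher number from compound 1 to compound 3 (0.10 log units; within the scatter)); both steps lie within the scatter. Compound 4 `COC(=O)[C@@H]1CCCC[C@@H]1c1ccc(C(F)(F)F)cc1` differs from compound 3 by trifluoromethyl in place of hydrogen on an aromatic carbon. Within the data shown here, the steps that bear on this change are the two at the same aromatic carbon, a 1.3-fold higher number from compound 1 to compound 3 (0.10 log units; within the scatter) and a 1.2-fold lower number from compound 2 to compound 3 (0.08 log units; within the scatter), neither of which left the scatter. No step beyond the scatter is therefore expected in this assay from compound 3 to compound 4. The estimated value for compound 4 is 950000 nM, with a range from 450000 nM to 2000000 nM. This estimate means an expected step of a 1.0-fold lower number from compound 3 to compound 4 (0.01 log units; within the scatter).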

Compound 4, inhibition constant: 222000 nM
Estimate against measurement, compound 4: 4.3-fold (0.63 log units) above, and the stated range ends above it.
By their numbers in this assay, from the lowest: compound 4; then compounds 1, 3 and 2 (each within the scatter of the next).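

In this assay, this aromatic carbon had shown no step beyond the scatter among hydrogen, tert-butyl and trifluoromethoxy, but trifluoromethyl does move the number, with a 4.4-fold lower number from compound 3 to compound 4 (0.64 log units; beyond the scatter). The group also separates from the other two substituents, with a 5.3-fold lower number from compound 2 to compound 4 (0.73 log units; beyond the scatter) and a 3.5-fold lower number from compound 1 to compound 4 (0.54 log units; beyond the scatter), so among these four groups only trifluoromethyl stands apart. Nothing available explains this difference. From the compounds shown here alone, it remains open whether a nitrile or a chlorine atom at this carbon would go with trifluoromethyl or with the other three groups. Going by these compounds, it is also open whether the step would persist if an amine replaced the methyl ester of the shared core.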